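Hydrazone aryl swap in a diaryl-ether urea series

This account rests on a few compounds, and the source may have more. Where it says the series, first, only, none or still open, it means among the compounds named here.

Measured compounds:
compound 1 `CN(C)CCn1cnnc1-c1cc(Oc2ccc(NC(=O)N/N=C/c3c(Cl)cccc3Cl)cc2F)ccn1` — > 100000 nM
compound 2 `COc1ccc(/C=N/NC(=O)Nc2ccc(Oc3ccnc(-c4nncn4CCN(C)C)c3)c(F)c2)c(OC)c1` — 12600 nM

In a functional assay on U-87MG ATCC cells (Homo sapiens) for cytotoxicity, read by MTT assay, with a stated time of 72 h (a higher number here means a weaker inhibitor, a lower number a stronger inhibitor), compound 1 gives > 100000 nM, which is a limit of the assay and not a number (the limit of > 100000 nM in this assay, at which 1 of the 2 values shown sits). In this assay compound 2 gives 12600 nM. Going by the values given here, this is the only actual number in the set. Among the compounds with values here, the one measured step, an at least 7.9-fold lower number from compound 1 to compound 2 (0.89 log units; beyond the scatter), is the only comparison available.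

Compound 3 `CN(C)CCn1cnnc1-c1cc(Oc2ccc(NC(=O)N/N=C/c3cccc(Cl)c3Cl)cc2F)ccn1` is not yet measured. It differs from compound 2 as follows (2,3-dichlorophenyl in place of 2,4-dimethoxyphenyl on a carbon with a double bond to nitrogen). The step from compound 2 to compound 3 is the reverse kind of change to the measured one: a dichlorophenyl returns in place of the 2,4-dimethoxyphenyl, though with the chlorines in a different arrangement than in compound 1. Since an at least 7.9-fold lower number from compound 1 to compound 2 (0.89 log units; beyond the scatter) was a lowering of the number on leaving a dichlorophenyl, the expectation is a raised number in this assay for compound 3, of uncertain size, with a real chance that only a limit is reported. For compound 3 the estimate in this assay is 40000 nM, with a range from 10000 nM to 150000 nM, which corresponds to an expected 3.2-fold higher number from compound 2 to compound 3 (0.50 log units; beyond the scatter).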

Compound 3, half-maximal inhibitory concentration: 13200 nM
Estimate against measurement, compound 3: 3.0-fold (0.48 log units) above; low and high end bracket the measured number.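

In this assay, a 1.0-fold higher number from compound 2 to compound 3 (0.02 log units; within the scatter), so on this carbon with a double bond to nitrogen the 2,3-dichlorophenyl and the 2,4-dimethoxyphenyl cannot be told apart, even though chlorine replaces the oxygen-bearing methoxy groups. The earlier pair left open whether chlorine on this ring was itself tied to the high reading, and the new compound argues against that: an at least 7.5-fold lower number from compound 1 to compound 3 (0.87 log units; beyond the scatter), with a change only in the arrangement of the chlorines, from 2,6-dichlorophenyl to 2,3-dichlorophenyl. For compound 1 the reading is a limit of the assay and not a number, so this step has a lower bound but no known size: the limit of > 100000 nM in this assay, at which 1 of the 3 values shown sits.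

The compounds shown do not separate the contribution of each chlorine, and a phenyl with one chlorine or none would be needed to tell which of them goes with the difference between compound 1 and compound 3. Also open, from the compounds shown here alone, is how this position responds to groups of a different kind, such as an amine or a carboxylic acid on the phenyl.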